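Extending the Carbamate Chain from Ethyl to Butyl

The source may report more compounds than this note shows. Statements on the series, on what has been measured and on what is new or still open speak of the compounds shown alone.

The three measured compounds share a selenium-bearing core with a carbamate on the aryl nitrogen. In a functional assay on PC-3 cells (Homo sapiens) for cytotoxicity, read by MTT assay, with a stated time of 72 h (on this read-out higher numbers stand for weaker inhibition of growth and lower numbers for stronger inhibition of growth), compound 2 `CCOC(=O)Nc1ccc([Se]C#N)cc1` gives 39200 nM. Compound 1 `CCCOC(=O)Nc1ccc([Se]C#N)cc1` gives 47400 nM in this assay, and the diselenide compound 3 `C=CCOC(=O)Nc1ccc([Se][Se]c2ccc(NC(=O)OCC=C)cc2)cc1` gives 49900 nM, so all three sit within the usual scatter of one another. Within the data shown here, the only single-point step among them, a 1.2-fold lower number from compound 1 to compound 2 (0.08 log units; within the scatter), concerns the same chain carbon that is changed here. Compound 4 `CCCCOC(=O)Nc1ccc([Se]C#N)cc1` differs from compound 2 by ethyl in place of hydrogen on a saturated chain carbon, two bonds along the chain from an oxygen next to a carbonyl group. Since the measured step in this region was within the scatter, the step of a 1.2-fold higher number from compound 2 to compound 4 (0.09 log units; within the scatter) is expected to be small as well. Compound 4 is therefore estimated at 48000 nM, with a range from 24000 nM to 96000 nM.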

Compound 4, concentration for total growth inhibition in the PC-3 assay: 40800 nM
Compound 4: the middle estimate sits 1.2-fold (0.07 log units) above what was measured; measured number inside the range.
By their numbers in the PC-3 assay, from the lowest: compounds 2, 4, 1 and 3 (each within the scatter of the next).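

In the PC-3 assay, the longer chain gives a 1.0-fold higher number from compound 2 to compound 4 (0.02 log units; within the scatter), and a further comparison gives a 1.2-fold lower number from compound 1 to compound 4 (0.07 log units; within the scatter). With both steps within the scatter, this read-out does not separate compound 1, compound 2 and compound 4. In a physicochemical assay, with a stated time of 6 min, tested at 0.1 mg/mL (on this read-out lower numbers stand for less inhibition and higher numbers for more inhibition at the one concentration tested (going by the name of the read-out)), however, compound 2 gives 26.3% and compound 4 gives 12.6%, a number 13.7 percentage points lower from compound 2 to compound 4 (beyond the scatter), so the same change shows up beyond the scatter there.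

Going by these compounds, whether the PC-3 assay stays this flat with a chain longer than butyl, or with an amine or carboxylic acid at the chain end, remains open.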